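Replacing the Diol Tail with a Carboxy Chain

This account rests on a few compounds, and the source may have more. Where it says the series, first, only, none or still open, it means among the compounds named here.

Compound 1 `CCC(CC)(c1ccc(OCC(O)CO)c(C)c1)c1ccc(OCC(O)C(C)(C)C)c(OCC(O)C(C)(C)C)c1` is the reference point; in an assay on cells for binding affinity to vitamin D3 receptor (Homo sapiens), read by fluorescence, tested at 1 uM (a lower number here means less inhibition, a higher number more inhibition at the concentration tested (going by the name of the read-out)), compound 1 gives 78%. Compound 2 `CCC(CC)(c1ccc(OCCCCO)c(C)c1)c1ccc(OCC(O)C(C)(C)C)c(OCC(O)C(C)(C)C)c1` gives 71%, within the scatter of compound 1, while compound 3 `CCC(CC)(c1ccc(OCCCCCO)c(C)c1)c1ccc(OCC(O)C(C)(C)C)c(OCC(O)C(C)(C)C)c1` gives 67%, beyond it. Compound 4 `CCC(CC)(c1ccc(OCCCC(=O)O)c(C)c1)c1ccc(OCC(O)C(C)(C)C)c(OCC(O)C(C)(C)C)c1` differs from compound 1 in one place: 2-carboxyethyl in place of 1,2-dihydroxyethyl on a saturated chain carbon bound to an oxygen on an aromatic ring. The measured steps that bear on this also swap the same 1,2-dihydroxyethyl group for a longer chain with a single hydroxy group: a number 7 percentage points lower from compound 1 to compound 2 (within the scatter) and a number 11 percentage points lower from compound 1 to compound 3 (beyond the scatter). Among the compounds with values here, both lean downward, and no measured step covers a 2-carboxyethyl group. A modestly lower number is therefore expected for compound 4, a number 16 percentage points lower from compound 1 to compound 4 (beyond the scatter). The estimate for compound 4 is 62%, with a range from 40% to 80%.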

Compound 4, a percentage reported as inhibition, at one concentration (the size of the read-out at that concentration, not a potency): 14%
For compound 4 the middle estimate is 48 percentage points above the measured one, and the stated range ends above it.
By their numbers in this assay, from the lowest: compound 4; then compounds 3, 2 and 1 (each within the scatter of the next, the first and the last beyond it).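

Changing the diol tail to a chain ending in a carboxy group gives a far larger change in this assay (a number 64 percentage points lower from compound 1 to compound 4 (beyond the scatter)). The chains ending in a single hydroxy group show the same gap (a number 57 percentage points lower from compound 2 to compound 4 (beyond the scatter); a number 53 percentage points lower from compound 3 to compound 4 (beyond the scatter)), so at this position the carboxy end counts for far more than the earlier tail changes did. Nothing measured here gives a reason for this drop. As far as these compounds go, whether a methyl ester or an amide at the chain end would restore the number remains open, as does the effect of a longer chain carrying the carboxy group.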